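This account rests on a few compounds, and the source may have more. Where it says the series, first, only, none or still open, it means among the compounds named here.

Measured so far:
Compound 1 `Cc1ccc(C(=O)Nc2ccc(CNC(=O)OCc3cccnc3)cc2)c(N2CCCC2)c1`: in a toxicity assay on GES1 cells (Homo sapiens) for inhibition, read by MTT assay, with a stated time of 72 h (a lower number here means a stronger inhibitor, a higher number a weaker inhibitor), compound 1 gives > 100000 nM, which is a limit of the assay rather than a number.
Compound 2 `Cc1ccc(N2CCCC2)c(C(=O)Nc2ccc(CNC(=O)OCc3cccnc3)cc2)c1`: in this assay compound 2 gives > 100000 nM, again a limit rather than a number.
Compound 3 `O=C(NCc1ccc(NC(=O)c2cccc(F)c2N2CCCC2)cc1)OCc1cccnc1`: in this assay compound 3 gives > 100000 nM, once more a limit rather than a number.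

For the measured compounds named here, compound 2 therefore stands exactly where every compound tested so far stands: at the limit of > 100000 nM in this assay, at which 3 of the 3 values shown sit, so no compound can be ranked against another, and no single-point step between measured compounds can be drawn, since the three compounds differ from one another in more than one place.

The next compound, compound 4 `O=C(NCc1ccc(NC(=O)c2cc(Br)ccc2N2CCCC2)cc1)OCc1cccnc1`, is reached from compound 2 by one change: bromo in place of methyl on an aromatic carbon.

Nothing measured here separates a bromo from a methyl at that aromatic carbon, and the whole series sits at the limit. The step of a number no higher from compound 2 to compound 4 (the limit leaves the size open) is expected to be none beyond the usual scatter. Compound 4 is expected to give about 100000 nM in this assay, with a likely range from 40000 nM to 300000 nM, and the most probable outcome is that the assay again reports only a limit and no number.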

Compound 4, half-maximal inhibitory concentration: > 100000 nM
Compound 4: no number, only a limit; the forecaster's own chance of this, stated with the estimate: 80%; the middle value sits exactly at the limit.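

Compound 2 and compound 4 each give only a limit rather than a number, so no step can be read for bromo in place of methyl in this assay: the limit of > 100000 nM in this assay, at which 4 of the 4 values shown sit. The compounds shown leave open whether bromo and methyl at that aromatic carbon differ at all in this assay, and how any of these compounds ranks against another.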